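A few compounds are considered here, and "the series" means these few. Any claim that something is new, unique, unknown or untested is made for them only; others in the source may bear on it.

Going by the values given here, compound 3, `CN1CCN(c2ccc3c(c2)oc(=O)n3C(=O)NCCCCc2ccccc2)C(=O)C1`, gives 52 nM in an assay on HEK293 cells for inhibition of acid ceramidase (Homo sapiens), read by fluorescence, with stated times of 10 min and 3 h (a higher number here means a weaker inhibitor, a lower number a stronger inhibitor), the lowest of the three numbers measured so far. Compound 2, `CN1CCC(c2ccc3c(c2)oc(=O)n3C(=O)NCCCCc2ccccc2)CC1=O`, gives 105 nM in this assay, and compound 1, `CC(C)N1CCN(c2ccc3c(c2)oc(=O)n3C(=O)NCCCCc2ccccc2)CC1`, gives 211 nM. The steps into compound 3 are a 2.0-fold lower number from compound 2 to compound 3 (0.31 log units; beyond the scatter) and a 4.1-fold lower number from compound 1 to compound 3 (0.61 log units; beyond the scatter), the first modest, the second larger and clearly beyond the scatter.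

Compound 4, `CC(C)CN1CCN(c2ccc3c(c2)oc(=O)n3C(=O)NCCCCc2ccccc2)CC1`, has not yet been measured. It differs from compound 3 in one place: 4-isobutylpiperazin-1-yl in place of 4-methyl-2-oxopiperazin-1-yl on an aromatic carbon. This change undoes much of what separated compound 1 from compound 3, as compound 1 also carried a piperazine with a branched alkyl group and without a ring carbonyl. The step that bears most directly on it is a 4.1-fold lower number from compound 1 to compound 3 (0.61 log units; beyond the scatter), read in reverse; the step of a 2.0-fold lower number from compound 1 to compound 2 (0.30 log units; within the scatter) is within the scatter and only shows that compound 1 sits at the weaker end of the set. Compound 4 is therefore expected to move back toward the number of compound 1, with an estimated step of a 3.5-fold higher number from compound 3 to compound 4 (0.54 log units; beyond the scatter). The estimate for compound 4 in this assay is 180 nM, with a range from 70 nM to 450 nM.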

Compound 4, half-maximal inhibitory concentration: 127 nM
For compound 4 the middle estimate is 1.4-fold (0.15 log units) above the measured one; low and high end bracket the measured number.
By their numbers in this assay, from the lowest: compound 3; then compounds 2, 4 and 1 (each within the scatter of the next).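

In this assay, a 2.4-fold higher number from compound 3 to compound 4 (0.39 log units; beyond the scatter) shows that the advantage of 4-methyl-2-oxopiperazin-1-yl on this aromatic carbon holds against a second piperazine bearing a branched alkyl group, and compound 3 stays the strongest inhibitor of the four, with its steps to all the others beyond the scatter. Isobutyl in place of isopropyl on the ring amine nitrogen gives a 1.7-fold lower number from compound 1 to compound 4 (0.22 log units; within the scatter), and the other new step, a 1.2-fold higher number from compound 2 to compound 4 (0.08 log units; within the scatter), is also within the scatter, so this assay does not separate compound 4 from compound 1 or from compound 2, and the change of branched alkyl group has no effect that can be read here. No measurement is available that would explain the difference between the oxopiperazine and the alkyl piperazines.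

Compound 3 and compound 4 differ in both the ring carbonyl and the alkyl group on the nitrogen, so the step cannot be assigned to either feature alone. A 4-methylpiperazin-1-yl or a 4-isobutyl-2-oxopiperazin-1-yl group at this position would separate the two, and the compounds shown also leave open how an unsubstituted ring amine or a longer chain on that nitrogen would read.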